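A few compounds are considered here, and "the series" means these few. Any claim that something is new, unique, unknown or untested is made for them only; others in the source may bear on it.

Series notes on a physicochemical assay for solubility, at pH 6.8; on this read-out higher numbers stand for higher solubility and lower numbers for lower solubility. Compound 1 `O=[N+]([O-])c1cn2c(n1)OC[C@@H](NCc1ccc(OC(F)(F)F)c(Cl)c1)C2` gives 77 ug/mL. Compound 2 `CN(Cc1ccc(OC(F)(F)F)cc1)[C@@H]1COc2nc([N+](=O)[O-])cn2C1` gives 10 ug/mL. Compound 3 `O=[N+]([O-])c1cn2c(n1)OC[C@@H](NCc1ccc(OC(F)(F)F)cc1Cl)C2` gives 30 ug/mL, the second highest of the three numbers: below compound 1 and above compound 2, with both gaps beyond the scatter. Compound 4 `O=[N+]([O-])c1cn2c(n1)OC[C@@H](NCc1ccc(OC(F)(F)F)cc1OC1CC1)C2` has not yet been measured in this assay. It differs from compound 3 in one place: cyclopropyloxy in place of chloro on an aromatic carbon. Among the compounds with values here, no measured pair in this set tracks such a change, so nothing here shows how the read-out answers it. The expected step is a 1.2-fold lower number from compound 3 to compound 4 (0.08 log units; within the scatter), judged likely to fall within the scatter and, if anything, downward. Compound 4 is therefore estimated at 25 ug/mL, with a range from 8 ug/mL to 70 ug/mL.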

Compound 4, solubility: 11 ug/mL
Compound 4: middle estimate off by 2.3-fold (0.36 log units), on the high side; the range from low to high includes it.
By their numbers in this assay, from the lowest: compounds 2 and 4 (each within the scatter of the next); then compound 3; then compound 1.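

In this assay, cyclopropyloxy in place of chloro on the aromatic carbon ortho to a large group and meta to the trifluoromethoxy group gives a 2.7-fold lower number from compound 3 to compound 4 (0.44 log units; beyond the scatter), so the read-out does respond to a change at this position. Within the data shown here, this is the only pair in the set that differs in one place, and the earlier compounds could not show this. Nothing measured here accounts for the step. One pair cannot separate the loss of chloro from the entry of the cyclopropyloxy group. On these data alone, how a methoxy group or an amine on this carbon would read remains open.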